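Swapping phenyl for naphthalen-2-yl in compound 3

The source may hold more compounds than are shown below. What is called first, only, known or untested is meant among the compounds shown, and "the series" means these compounds.

Within the data shown here, in a functional assay on SW-620 cells (Homo sapiens) for cytotoxicity, read by MTT assay, with stated times of 4 h and 72 h, tested at 2 uM (on this read-out higher numbers stand for weaker inhibition and lower numbers for stronger inhibition), compound 3 `Cc1cc(Nc2ccc(C(=O)/C=C/c3ccccc3)cc2)n2nc(SCc3nc4ccccc4[nH]3)nc2n1` gives 130 nM and so sits in the middle of the three numbers known so far. Compound 1 `Cc1ccc(/C=C/C(=O)c2ccc(Nc3cc(C)nc4nc(SCc5nc6ccccc6[nH]5)nn34)cc2)cc1` reads 1520 nM on the high side, and compound 2 `Cc1cc(Nc2ccc(C(=O)/C=C/c3ccc4ccccc4c3)cc2)n2nc(SC(=O)c3csc4ccc(Cl)cc34)nc2n1` reads 35 nM on the low side. Unmeasured compound 4 `Cc1cc(Nc2ccc(C(=O)/C=C/c3ccc4ccccc4c3)cc2)n2nc(SCc3nc4ccccc4[nH]3)nc2n1` has naphthalen-2-yl in place of phenyl on a double-bonded chain carbon bound to a double-bonded chain carbon. Among the measured compounds shown here, one measured step touches that end of the molecule: a 12-fold lower number from compound 1 to compound 3 (1.07 log units; beyond the scatter) when hydrogen replaces methyl on an aromatic carbon. This large step hints that extra carbon there can raise the number, yet compound 2 also carries naphthalen-2-yl and gives 35 nM while differing elsewhere. A small upward step, perhaps none beyond the scatter, is expected (a 1.4-fold higher number from compound 3 to compound 4 (0.14 log units; within the scatter)). In this assay compound 4 is estimated at 180 nM (expected range 45 nM to 800 nM).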

Compound 4, half-maximal inhibitory concentration: 5 nM
The estimate for compound 4 lay 36-fold (1.56 log units) above the measured number, outside the stated range (below it).
By their numbers in this assay, from the lowest: compound 4; then compound 2; then compound 3; then compound 1.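

In this assay, enlarging phenyl to naphthalen-2-yl on the double-bonded chain carbon strengthens inhibition sharply (a 26-fold lower number from compound 3 to compound 4 (1.41 log units; beyond the scatter)), while the methyl on compound 1 weakens it (a 12-fold lower number from compound 1 to compound 3 (1.07 log units; beyond the scatter)), so added carbon here does not act in one direction. Naphthalen-2-yl also outperforms 4-methylphenyl (a 300-fold lower number from compound 1 to compound 4 (2.48 log units; beyond the scatter)). With naphthalen-2-yl fixed, the sulfur substituent still matters, as (1H-benzimidazol-2-yl)methyl outperforms (5-chloro-1-benzothiophen-3-yl)carbonyl (a 7.0-fold lower number from compound 2 to compound 4 (0.85 log units; beyond the scatter)). From the compounds shown here alone, whether an amine or a carboxylic acid at this chain carbon would keep such low numbers stays open. Nothing available explains the gain from naphthalen-2-yl.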